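A Free Acid Replaces an Ester on the Shared Core

This account rests on a few compounds, and the source may have more. Where it says the series, first, only, none or still open, it means among the compounds named here.

compound 1 `CCOC(=O)COc1c(-c2ccc(OC)cc2)oc2c(CC=C(C)C)c(O)cc(O)c2c1=O`: > 100000 nM
compound 2 `COc1ccc(-c2oc3c(CC=C(C)C)c(OCCOC(=O)CCC(=O)O)cc(O)c3c(=O)c2OCCOC(=O)CCC(=O)O)cc1`: > 100000 nM
compound 3 `CCOC(=O)C(C)Oc1cc(O)c2c(=O)c(O)c(-c3ccc(OC)cc3)oc2c1CC=C(C)C`: > 100000 nM

All three measured compounds were tested in a functional assay on MCF7 cells (Homo sapiens) for cytotoxicity, read by MTT assay; a lower number here means a stronger inhibitor, a higher number a weaker inhibitor. Each of these values is a limit of the assay, not a number. Compound 3 therefore stands at the limit, and nothing places it above or below the other two; the whole picture is the limit of > 100000 nM in this assay, at which 3 of the 3 values shown sit. Within the data shown here, no step between two measured compounds can be computed, so no direction has been observed.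

Compound 4 `COc1ccc(-c2oc3c(CC=C(C)C)c(OC/C=C/C(=O)O)cc(O)c3c(=O)c2O)cc1` differs from compound 3 in one place: 3-carboxyprop-2-en-1-yl in place of 1-(ethoxycarbonyl)ethyl on an oxygen on an aromatic ring. With every measured compound sitting at the limit, the expected step that the limit leaves unreadable from compound 3 to compound 4 is none beyond the scatter, and a limit is again the most likely outcome. Compound 4 is estimated at 150000 nM, within a range from 40000 nM to 600000 nM.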

Compound 4, half-maximal inhibitory concentration: > 100000 nM
Compound 4: no number, only a limit (the forecaster's own chance of this, stated with the estimate: 75%); the middle value lies beyond the limit too.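

Compound 4 gives only a limit of the assay, as compound 3 does, so no step between them can be read: the limit of > 100000 nM in this assay, at which 4 of the 4 values shown sit.

The compounds shown leave open which change on the shared core, if any, would yield a measurable value.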